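Cyclobutyl to cyclopentyl: little change in cytotoxicity expected

The compounds below may be only part of what the source reports. "The series", "measured", "known", "first", "only" and "open" are said of these compounds alone.

In an ADME assay on Vero cells (Chlorocebus sabaeus) for cytotoxicity, read by CellTiter-Glo, with a stated time of 72 h (on this read-out lower numbers stand for higher toxicity in this test and higher numbers for lower toxicity in this test), compound 3 `[O-][n+]1nc(NC2CCC2)[n+]([O-])c2ccc(Br)cc21` gives 3.8 ug/mL. Compound 2 `CCNc1n[n+]([O-])c2cc(Br)ccc2[n+]1[O-]` gives 4.2 ug/mL, and these two numbers lie within the usual scatter of each other. Compound 1 `[O-][n+]1nc(NC2CCCC2)[n+]([O-])c2ccccc21` gives 10 ug/mL, a number beyond the scatter from that of compound 3, although the two structures differ in more than one place.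

Compound 4 `[O-][n+]1nc(NC2CCCC2)[n+]([O-])c2ccc(Br)cc21` carries cyclopentyl in place of cyclobutyl on a nitrogen on an aromatic ring. For the measured compounds named here, only one measured step touches this position, a 1.1-fold lower number from compound 2 to compound 3 (0.04 log units; within the scatter), where cyclobutyl took the place of ethyl. A single small step is thin evidence, but it gives no reason to expect a large change here. Compound 1 also carries cyclopentyl, and its higher number leaves some room upward. In this assay, the expected step is therefore a 1.2-fold higher number from compound 3 to compound 4 (0.07 log units; within the scatter), with no change beyond the scatter anticipated. Compound 4 is estimated at 4.5 ug/mL, with an expected range of 2.2 ug/mL to 9 ug/mL.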

Compound 4, half-maximal cytotoxic concentration: 18 ug/mL
Estimate against measurement, compound 4: 4.0-fold (0.60 log units) below; measured number outside the range, above it.
By their numbers in this assay, from the lowest: compounds 3 and 2 (each within the scatter of the next); then compounds 1 and 4 (each within the scatter of the next).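

In this assay, this position proves sensitive after all: cyclopentyl in place of cyclobutyl on the nitrogen gives a 4.7-fold higher number from compound 3 to compound 4 (0.68 log units; beyond the scatter), a step beyond the scatter and so a lower toxicity in this test. Cyclopentyl in place of ethyl gives a 4.3-fold higher number from compound 2 to compound 4 (0.63 log units; beyond the scatter), also beyond the scatter, so the cyclopentyl group stands apart from both smaller groups, even though ethyl and cyclobutyl lie within the scatter of each other. Bromo in place of hydrogen on an aromatic carbon gives a 1.8-fold higher number from compound 1 to compound 4 (0.26 log units; within the scatter), which lies within the scatter, so this pair shows no clear effect of the bromo group when cyclopentyl is present.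

The compounds shown leave open whether cyclohexyl or a longer chain such as butyl on this nitrogen would move the number further. Nothing available here accounts for the jump at cyclopentyl.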